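The source may hold more compounds than are shown below. What is called first, only, known or untested is meant among the compounds shown, and "the series" means these compounds.

Measured so far:
compound 1, `CCOC(=O)c1cc(=O)c2cc(CSC(=S)N(C(C)C)C(C)C)ccc2o1`; in a functional assay on HeLa cells (Homo sapiens) for antiproliferative activity, read by MTT assay, with a stated time of 72 h (on this read-out lower numbers stand for stronger inhibition and higher numbers for weaker inhibition), compound 1 gives > 25000 nM, which is a limit of the assay and not a number.
compound 2, `Cc1ccc2c(=O)c(CSC(=S)N(C(C)C)C(C)C)coc2c1`; in this assay compound 2 gives 1400 nM.

Compound 1 stands at the limit of > 25000 nM in this assay, at which 1 of the 2 values shown sits, so its standing can only be said as a limit. Going by the values given here, compound 2 has a number in this assay, but it differs from compound 1 in more than one place, and no single step between the two is tracked; the two values show only that one compound reaches a number and the other does not.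

Compound 3, `CCOC(=O)c1cc(=O)c2cc(CSC(=S)N3CCCCC3)ccc2o1`, is not yet measured. It differs from compound 1 by piperidin-1-yl in place of diisopropylamino on a thiocarbonyl carbon. The rest of the shared core, including the ester, is kept. Among the compounds with values here, no measured step of this kind exists, so the expectation for this assay is no move beyond the usual scatter, and compound 3 is expected to remain at the limit. The step from compound 1 to compound 3 is therefore estimated as a number no higher from compound 1 to compound 3 (the limit leaves the size open). Compound 3 is expected to give 25000 nM, within 8000 nM to 60000 nM.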

Compound 3, half-maximal inhibitory concentration: 5800 nM
The estimate for compound 3 lay 4.3-fold (0.63 log units) above the measured number; the measured number lies below the stated range.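

In this assay, going by these compounds alone, piperidin-1-yl in place of diisopropylamino on a thiocarbonyl carbon gives an at least 4.3-fold lower number from compound 1 to compound 3 (0.63 log units; beyond the scatter), the first single-place step and one that lies beyond the scatter. With the ester and the rest of the shared core kept, this place is therefore not silent, and a compound carrying that ester can reach a number in this read-out. Compound 1 stands at a limit of the assay and not at a number, so the step has only a lower bound and its full size stays open: the limit of > 25000 nM in this assay, at which 1 of the 3 values shown sits.

Compound 3 alone cannot separate the presence of the ring from the other differences between the two groups, and diethylamino, pyrrolidin-1-yl or morpholin-4-yl on the same thiocarbonyl carbon would bear on that question. Within the data shown here, it also remains open whether the same change carries over to the core of compound 2, which differs from compound 1 in more than one place and so gives no step here.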